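Replacing the Aryl Ring on the Sulfonyl Group

This account rests on a few compounds, and the source may have more. Where it says the series, first, only, none or still open, it means among the compounds named here.

Three measured compounds share a core in which an aromatic ring hangs from a sulfonyl sulfur. In an assay on HeLa cells for displacement of a labelled ligand from 5-hydroxytryptamine receptor 6 (Homo sapiens) (on this read-out lower numbers stand for stronger inhibition and higher numbers for weaker inhibition), compound 1 `CC(C)n1nc(S(=O)(=O)c2cccc3ccccc23)c2cc(N3CCN(C)CC3)ccc21` gives 1.8 nM, compound 2 `O=S(=O)(c1ccc(Cl)cc1)c1n[nH]c2cc(N3CCNCC3)ccc12` gives 110 nM, and compound 3 `Cc1ccc(S(=O)(=O)c2n[nH]c3ccc(N4CCN(C)CC4)cc23)cc1` gives 4.9 nM. Compound 3 therefore holds the second highest number of the three: it sits beyond the scatter above compound 1 and far below compound 2. Compound 4 `CN1CCN(c2ccc3[nH]nc(S(=O)(=O)c4c(Cl)cccc4Cl)c3c2)CC1` differs from compound 3 in one place only: 2,6-dichlorophenyl in place of 4-methylphenyl on a sulfonyl sulfur. Among the compounds with values here, no measured pair shows this exact change, so the expectation rests on the structure alone, and only a small step is anticipated, in either direction or none beyond the scatter. For compound 4 the estimated value in this assay is 5 nM, within 1.5 nM to 20 nM, which corresponds to an expected step of a 1.0-fold higher number from compound 3 to compound 4 (0.01 log units; within the scatter).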

Compound 4, inhibition constant: 2.6 nM
The estimate for compound 4 lay 1.9-fold (0.28 log units) above the measured number, and the stated range covers the measured number.
By their numbers in this assay, from the lowest: compounds 1, 4 and 3 (each within the scatter of the next, the first and the last beyond it); then compound 2.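

On the sulfonyl sulfur, 2,6-dichlorophenyl in place of 4-methylphenyl gives a 1.9-fold lower number from compound 3 to compound 4 (0.28 log units; within the scatter) in this assay, so the two compounds cannot be told apart. Within the data shown here, the earlier compounds differed in more than one place, so this is the first pair to isolate the aryl ring at this position, and this swap of ring substituents leaves the number within the scatter. Nothing measured here explains the similar numbers. Still open, as far as these compounds go, is whether a phenyl ring carrying an amine or a carboxylic acid, instead of chlorine or methyl, would give a similar number.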